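The compounds below may be only part of what the source reports. "The series", "measured", "known", "first", "only" and "open" are said of these compounds alone.

Compound 1 `Cc1ccc(N2CCN(C(=O)c3oc(C)nc3-c3ccccc3)CC2)c(C)c1` gives 101 nM in a functional assay on HL-60 cells (Homo sapiens) for inhibition, read by MTT assay, with a stated time of 72 h; a higher number here means a weaker inhibitor, a lower number a stronger inhibitor.
Compound 2 `COc1cccc(N2CCN(C(=O)c3oc(C)nc3-c3ccc(F)cc3)CC2)c1` gives 112 nM.
Compound 3 `Cc1nc(-c2ccccc2Cl)c(C(=O)N2CCN(c3cccc(Cl)c3)CC2)o1` gives 132 nM.

Compound 1 carries the lowest number of the three in this assay, yet compound 2 and compound 3 both lie within the usual scatter of it, so none of the three can be called stronger or weaker than another. What the three share is the same core, and they differ only in the group attached to the amine nitrogen in a ring; across methyl, methoxy and chloro substituents on that group the numbers stay close together.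

The unmeasured compound 4 `COc1cc(OC)cc(N2CCN(C(=O)c3oc(C)nc3-c3ccccc3)CC2)c1` changes the same position again. Compared with compound 1, (3,5-dimethoxyphenyl in place of 2,4-dimethylphenyl on an amine nitrogen in a ring). The 3,5-dimethoxyphenyl brings two hydrogen-bond acceptors where the 2,4-dimethylphenyl had none, but otherwise the size and ring type are alike.

Going by the values given here, no direct step between two measured compounds covers this change. Since the other variations at this position left the numbers close, the step from compound 1 to compound 4 is expected to be a 1.3-fold higher number from compound 1 to compound 4 (0.11 log units; within the scatter), most likely within the scatter and with no clear direction. For compound 4 the estimate in this assay is 130 nM, with a range from 50 nM to 350 nM.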

Compound 4, half-maximal inhibitory concentration: 19.2 nM
Beside the measured number, compound 4's estimate is 6.8-fold (0.83 log units) above it, and the stated range ends above it.
By their numbers in this assay, from the lowest: compound 4; then compounds 1, 2 and 3 (each within the scatter of the next).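

In this assay, putting 3,5-dimethoxyphenyl in place of 2,4-dimethylphenyl on the amine nitrogen in a ring gives a 5.3-fold lower number from compound 1 to compound 4 (0.72 log units; beyond the scatter), which shows that a change at this position can move the number beyond the scatter. The earlier compounds shown here, whose numbers all lay close together, gave no sign of this. This single step alters two things at once, the kind of substituent on the phenyl ring and the places it occupies, as the two group names show, and the entering group also brings hydrogen-bond acceptors that the leaving group lacks. No measurement at hand explains the lower number.

The compounds shown leave open whether the methoxy groups or the places they occupy account for the step, a question that 3,5-dimethylphenyl and 2,4-dimethoxyphenyl at this position could help to separate. They also leave open how far this position tolerates further change, for instance 3,5-diethoxyphenyl with its longer chains or 3,5-dihydroxyphenyl with hydroxyl groups in place of the methoxy groups.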